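Benzylamino for pyrrolidinyl on a fused quinone core

The compounds below may be only part of what the source reports. "The series", "measured", "known", "first", "only" and "open" are said of these compounds alone.

Measured compounds:
compound 1 `O=C1C(N2CCCC2)=CC(=O)c2nc(-c3ccccc3)ccc21` gives 44700 nM;
compound 2 `Cc1ccc2c(n1)C(=O)C=C(N1CC1)C2=O` gives 513 nM;
compound 3 `COc1cc(-c2ccc3c(n2)C(=O)C(NCc2ccccc2)=CC3=O)cc(OC)c1OC` gives 2690 nM.

In a functional assay on NCI60 cells (Homo sapiens) for cytotoxicity (a higher number here means a weaker inhibitor of growth, a lower number a stronger inhibitor of growth), compound 1 stands highest of the three numbers; compound 3 is nearest and compound 2 furthest, both gaps lying beyond the scatter. The step to compound 4 `O=C1C(NCc2ccccc2)=CC(=O)c2nc(-c3ccccc3)ccc21` is benzylamino in place of pyrrolidin-1-yl on a double-bonded ring carbon. Going by the values given here, no measured pair shows this exact change. Compound 3 carries the same benzylamino group on a related core and gives 2690 nM, so a drop in number, well beyond the scatter, is expected for compound 4; the size of a 15-fold lower number from compound 1 to compound 4 (1.17 log units; beyond the scatter) is the estimated step. Compound 4 is thus estimated at 3000 nM, in the range 800 nM to 12000 nM.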

Compound 4, concentration for 50% growth inhibition: 1700 nM
Beside the measured number, compound 4's estimate is 1.8-fold (0.25 log units) above it, and the stated range covers the measured number.
By their numbers in this assay, from the lowest: compound 2; then compounds 4 and 3 (each within the scatter of the next); then compound 1.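

In this assay benzylamino in place of pyrrolidin-1-yl on a double-bonded ring carbon gives a 26-fold lower number from compound 1 to compound 4 (1.42 log units; beyond the scatter). Going by these compounds alone, this is the first pair in which only this group differs, and it shows that the substituent at this carbon alone can shift growth inhibition well beyond the scatter. Nothing measured here accounts for the step. Still open, on these data alone, is whether the benzene ring or the hydrogen on the nitrogen matters more: cyclohexylmethylamino would test the first, and N-methylbenzylamino the second.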